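Adding a Methyl to Compound 3: What to Expect

A few compounds are considered here, and "the series" means these few. Any claim that something is new, unique, unknown or untested is made for them only; others in the source may bear on it.

Compound 1 `CC1=NN(c2cccc(Cl)c2)C(=O)C12C=CC(=O)C=C2c1ccc(C)cc1`: 9050 nM
Compound 2 `CC1=NN(c2ccc(Br)cc2)C(=O)C12C=CC(=O)C=C2c1ccc(C)cc1`: 27400 nM
Compound 3 `CC1=NN(c2ccccc2)C(=O)C12C=CC(=O)C=C2c1ccccc1`: 16500 nM

In a functional assay on A549 cells (Homo sapiens) for antiproliferative activity, read by CCK-8 assay, with a stated time of 72 h (on this read-out lower numbers stand for stronger inhibition and higher numbers for weaker inhibition), compound 3 gives 16500 nM, the second highest of the three numbers, although its gaps to compound 2 and to compound 1 both lie within the scatter. Compound 4 `CC1=NN(c2ccccc2)C(=O)C12C=CC(=O)C=C2c1ccc(C)cc1` differs from compound 3 by methyl in place of hydrogen on an aromatic carbon. Within the data shown here, the only measured step, a 3.0-fold higher number from compound 1 to compound 2 (0.48 log units; beyond the scatter), concerns the group on the amide-type nitrogen and not this position, so no measured step bears directly on the change; compound 1 and compound 2 carry the 4-methylphenyl but differ from compound 3 in other places as well. The expectation is therefore a step of no more than the scatter, a 1.1-fold lower number from compound 3 to compound 4 (0.04 log units; within the scatter). Compound 4 is estimated at 15000 nM, within the range 6000 nM to 40000 nM.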

Compound 4, half-maximal inhibitory concentration: 19300 nM
For compound 4 the middle estimate is 1.3-fold (0.11 log units) below the measured one, within the range that was stated.
By their numbers in this assay, from the lowest: compounds 1, 3, 4 and 2 (each within the scatter of the next, the first and the last beyond it).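

In this assay, the change from phenyl to 4-methylphenyl gives a step within the scatter (a 1.2-fold higher number from compound 3 to compound 4 (0.07 log units; within the scatter)), so this position accepts the methyl with no clear shift in the number. With the 4-methylphenyl held fixed, hydrogen in place of bromo on the other aromatic ring stays within the scatter (a 1.4-fold lower number from compound 2 to compound 4 (0.15 log units; within the scatter)), whereas hydrogen in place of chloro lies just beyond it (a 2.1-fold higher number from compound 1 to compound 4 (0.33 log units; beyond the scatter)). No measurement shown here accounts for these steps. The compounds shown carry only hydrogen or methyl at this position. As far as these compounds go, whether an amine or a carboxylic acid there would move the number beyond the scatter remains open.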